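Swapping Methylamino for Methoxy on a Shared Core

This account rests on a few compounds, and the source may have more. Where it says the series, first, only, none or still open, it means among the compounds named here.

Of the compounds shown here, three built on the same core have been tested in a functional assay on the whole organism with Rattus norvegicus as the target, at a dose of 40 mg/kg by the intraperitoneal route; on this read-out higher numbers stand for more inhibition at the one dose given (going by the name of the read-out) and lower numbers for less inhibition. Compound 1 `Cc1nc2c(OCc3ccccc3)cccn2c1/N=C/N(C)C` gives 64%. Compound 2 `CNc1c(C)nc2c(OCc3ccccc3)cccn12` gives 55%, which places it second highest of the three numbers; its nearest neighbour is compound 3 `CCNc1c(C)nc2c(OCc3ccccc3)nccn12`, which gives 48%, and the gap from compound 2 to compound 1 is also within the scatter, as is the gap to compound 3.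

Compound 4 `COc1c(C)nc2c(OCc3ccccc3)cccn12` differs from compound 2 by methoxy in place of methylamino on an aromatic carbon. For the measured compounds named here, no measured pair shows methoxy replacing methylamino at this carbon, and the only measured step at this position is a number 9 percentage points lower from compound 1 to compound 2 (within the scatter), a change that stayed within the scatter. Going by the values given here, with that as the sole guide, the expected step of a number 7 percentage points lower from compound 2 to compound 4 (within the scatter) is one that does not go beyond the scatter. Compound 4 is estimated to give 48% in this assay, with a likely range from 30% to 66%.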

Compound 4, a percentage reported as inhibition, in the whole organism at one dose (the size of the read-out at that dose, not a potency): 49%
Estimate against measurement, compound 4: 1 percentage points below; the measured number falls inside the stated range.
By their numbers in this assay, from the lowest: compounds 3, 4, 2 and 1 (each within the scatter of the next, the first and the last beyond it).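

In this assay, for the compounds shown here, the change from methylamino, with 1 hydrogen-bond donor, to methoxy, with 0, gives a number 6 percentage points lower from compound 2 to compound 4 (within the scatter) and is the first direct test of this swap at this aromatic carbon. The number therefore does not separate from that of the methylamino compound, so at this one dose the donor count is not shown to matter here. Going by these compounds alone, replacing the larger group of compound 1 with methoxy gives a number 15 percentage points lower from compound 1 to compound 4 (beyond the scatter) and is the first step at this position to pass the scatter, though only modestly. Nothing available explains either step.

Going by these compounds, whether a free amine, a hydroxyl group or a longer chain such as ethoxy at this carbon would fit with these numbers remains open. A single dose also leaves any difference in potency unresolved.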